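An Epimer Near the Cytotoxicity Limit

The source may hold more compounds than are shown below. What is called first, only, known or untested is meant among the compounds shown, and "the series" means these compounds.

Three compounds have been examined in an ADME assay on SNB-19 cells (Homo sapiens) for cytotoxicity, read by MTT assay, with a stated time of 24 h; on this read-out higher numbers stand for lower toxicity in this test and lower numbers for higher toxicity in this test. Compound 1 `C=C1CC[C@H]2[C@@](C)(CCC(=O)[C@@]2(C)COC(C)=O)[C@@H]1C/C=C1/C(=O)OC[C@H]1Oc1c(Cl)cc(Cl)c2cccnc12` reaches only the limit of this assay: compound 1 gives > 100000 nM, which is a limit rather than a number (the limit of > 100000 nM in this assay, at which 1 of the 3 values shown sits). Compound 2 `C=C1CC[C@@H]2[C@](C)(COC(C)=O)[C@H](O)CC[C@@]2(C)[C@@H]1C/C=C1/C(=O)OC[C@@H]1Oc1cccc2cccnc12` gives 49500 nM in this assay. Compound 3 `C=C1CC[C@@H]2[C@](C)(CO)[C@H](O)CC[C@@]2(C)[C@@H]1C/C=C1/C(=O)OC[C@@H]1Oc1ccnc2ccccc12` gives 61200 nM in this assay. Compound 1 therefore stands at the limit, while compound 2 and compound 3 return numbers inside the measured range.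

Compound 4 `C=C1CC[C@H]2[C@@](C)(CCC(=O)[C@@]2(C)COC(C)=O)[C@@H]1C/C=C1/C(=O)OC[C@@H]1Oc1c(Cl)cc(Cl)c2cccnc12` has not yet been measured. Relative to compound 1 the change is the two compounds have the same atoms and bonds and differ only in configuration as drawn: 1 of 6 stereo elements differ; a stereocentre at a saturated ring carbon is drawn S in compound 1 and R in compound 4: the two compounds have the same atoms and bonds and differ only in configuration as drawn. Among the compounds with values here, no step between two measured compounds bears on such a change, so the step from compound 1 to compound 4 in this assay is expected to be none beyond the scatter. Compound 4 is therefore estimated at 100000 nM, with a range from 50000 nM to 200000 nM. The expected step of a number no higher from compound 1 to compound 4 (the limit leaves the size open) is accordingly small, and a limit rather than a number is the likelier outcome.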

Compound 4, half-maximal cytotoxic concentration: 72000 nM
Compound 4: middle estimate off by 1.4-fold (0.14 log units), on the high side; the range from low to high includes it.
By their numbers in this assay, from the lowest: compounds 2, 3 and 4 (each within the scatter of the next). At a limit, above all of these: compound 1.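

Within the data shown here, with the stereocentre at a saturated ring carbon drawn R rather than S, this assay gives an at least 1.3-fold lower number from compound 1 to compound 4 (0.14 log units; that floor lies within the scatter), the first reading on a change of configuration alone at this position. The value of compound 1 is a limit and not a number, so only a floor for this step can be read, and that floor does not go beyond the usual scatter: the limit of > 100000 nM in this assay, at which 1 of the 4 values shown sits. Because no atom or bond changes, whatever difference exists between this pair can lie only in the configuration of this one stereocentre: the fact that compounds 1 and 4 differ only in the configuration as drawn

The compounds shown leave open how far the real step lies beyond that floor. They also leave open whether the same change of configuration would give a similar step in a compound carrying an amine or a carboxylic acid on the shared core.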